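From 3-nitrophenyl to 4-chlorophenyl: An Expected Growth-Inhibition Result

This account rests on a few compounds, and the source may have more. Where it says the series, first, only, none or still open, it means among the compounds named here.

Of the compounds shown here, two sharing one core have been tested so far in a functional assay on NCI/ADR cells (Homo sapiens) for cytotoxicity, read by sulforhodamine B assay; on this read-out higher numbers stand for weaker inhibition of growth and lower numbers for stronger inhibition of growth. Compound 1 `CC1=CC[C@@H]([C@@](C)(O)CCCC(C)(C)NC(=S)N/N=C\c2ccccc2[N+](=O)[O-])CC1` gives > 100000 nM, which is a limit of the assay and not a number. For the measured compounds named here, compound 2 `CC1=CC[C@@H]([C@@](C)(O)CCCC(C)(C)NC(=S)N/N=C\c2cccc([N+](=O)[O-])c2)CC1` gives 38000 nM, so it holds the only actual number available in this assay.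

The next compound, compound 3 `CC1=CC[C@@H]([C@@](C)(O)CCCC(C)(C)NC(=S)N/N=C\c2ccc(Cl)cc2)CC1`, differs from compound 2 in one place: 4-chlorophenyl in place of 3-nitrophenyl on a carbon with a double bond to nitrogen. In words, 4-chlorophenyl stands in place of 3-nitrophenyl on a carbon with a double bond to nitrogen.

Going by the values given here, only one measured step bears on this change. That step, an at least 2.6-fold lower number from compound 1 to compound 2 (0.42 log units; beyond the scatter), shows that changing this group can shift the result beyond the scatter. However, it compares two nitrophenyl groups, so it gives only a weak guide to a chlorophenyl group and does not set a direction.

The estimated step, a 1.3-fold lower number from compound 2 to compound 3 (0.10 log units; within the scatter), is therefore expected to stay within the usual scatter. For compound 3, the expected value is 30000 nM, with an estimated range from 6000 nM to 100000 nM.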

Compound 3, concentration for total growth inhibition: 36400 nM
Beside the measured number, compound 3's estimate is 1.2-fold (0.08 log units) below it, within the range that was stated.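

In this assay, the change from 3-nitrophenyl to 4-chlorophenyl on a carbon with a double bond to nitrogen gives a 1.0-fold lower number from compound 2 to compound 3 (0.02 log units; within the scatter), so a ring carrying chlorine and no nitro group reads the same as compound 2 within the scatter. The change from 2-nitrophenyl to 4-chlorophenyl gives an at least 2.7-fold lower number from compound 1 to compound 3 (0.43 log units; beyond the scatter), which means that compound 2 and compound 3 each stand apart from compound 1 by more than the scatter, and a second group now shows this separation. The size of that separation can be read only as a minimum because the value of compound 1 is a limit of the assay and not a number: the limit of > 100000 nM in this assay, at which 1 of the 3 values shown sits.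

The nitro group and the chlorine also sit at different places on the ring, so these three compounds cannot separate the identity of the group from where it sits. From the compounds shown here alone, it also remains open how a plain phenyl group, or a phenyl group carrying an amine or a carboxylic acid, would read at this place.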